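The source may report more compounds than this note shows. Statements on the series, on what has been measured and on what is new or still open speak of the compounds shown alone.

Two compounds of the series have been run in a functional assay on SR cells (Homo sapiens) for cytotoxicity, read by sulforhodamine B assay, with a stated time of 48 h, tested at 1 uM; on this read-out higher numbers stand for a weaker effect at the one concentration tested and lower numbers for a stronger effect. Compound 1 `COc1ccc(-c2cc(/C=C/C(=O)c3ccc(N)cc3)[nH]n2)cc1` gives 45% in this assay. Compound 2 `COc1cc(-c2cc(/C=C/C(=O)c3ccc(N)cc3)[nH]n2)cc(OC)c1OC` gives 14% in this assay, the lowest of the two numbers; its nearest neighbour, compound 1, stands higher by a gap beyond the usual scatter, so compound 2 is the stronger of the pair at the one concentration tested. The two differ in more than one place, so no single step can be read from them.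

Compound 3 `COc1ccc(C(=O)/C=C/c2cc(-c3cc(OC)c(OC)c(OC)c3)n[nH]2)cc1` has not yet been measured. It differs from compound 2 in one place: methoxy in place of amino on an aromatic carbon. Among the compounds with values here, no measured pair in the set shares this change, so its effect on the read-out is unknown from the data. The guess leans toward a weaker effect, since the stronger of the two measured compounds, compound 2 with 14%, carries the amino group that is lost here. The expected shift is a number 36 percentage points higher from compound 2 to compound 3 (beyond the scatter), upward and beyond the scatter. Compound 3 is therefore estimated to give 50% in this assay, with a range from 20% to 85%.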

Compound 3, a percentage reported as activity, at one concentration (the size of the read-out at that concentration, not a potency): 22%
Compound 3: the middle estimate sits 28 percentage points above what was measured; the measured number falls inside the stated range.
By their numbers in this assay, from the lowest: compounds 2 and 3 (each within the scatter of the next); then compound 1.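

In this assay, the exchange of amino for methoxy on the aromatic carbon para to a large group, the cut that also reads as 4-aminophenyl to 4-methoxyphenyl, gives this step: a number 8 percentage points higher from compound 2 to compound 3 (within the scatter). Within the data shown here, this is the first single-place comparison, and it shows that the amino group, with the hydrogen-bond donor counted on it, can give way to methoxy at this position without a change that stands clear of the scatter, at the one concentration tested and on this one pair. No supporting measurement accompanies the pair to say why compound 2 and compound 3 read alike.

The compounds shown leave open whether a hydroxyl group, a dimethylamino group or a fluorine atom at this position would also read like amino and methoxy, or whether the tolerance is limited to these two groups. Also open, as far as these compounds go, is whether the same exchange would give a similar step with the 4-methoxyphenyl group of compound 1 in place of the trimethoxy-substituted ring of compound 2.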